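Trimethoxyphenyl series: aryl swap on the saturated ring carbon

The source may report more compounds than this note shows. Statements on the series, on what has been measured and on what is new or still open speak of the compounds shown alone.

Measured so far:
compound 1 `COc1cc(C2=NN(C(C)=O)C(c3cccc(F)c3)O2)cc(OC)c1OC` — 37.7%
compound 2 `COc1cc(C(=O)N/N=C/c2ccccc2C(F)(F)F)cc(OC)c1OC` — 35.6%

In a functional assay on BGC-823 cells (Homo sapiens) for antiproliferative activity, read by MTT assay, tested at 5 uM (on this read-out lower numbers stand for a weaker effect and higher numbers for a stronger effect at the one concentration tested), compound 1 gives 37.7%, the highest of the two numbers in hand. Compound 2 gives 35.6%, which sits within the scatter of compound 1, so no order between the two can be read. Among the measured compounds shown here, no step between measured compounds is available for this pair.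

Compound 3 `COc1cc(C2=NN(C(C)=O)C(c3ccccc3C(F)(F)F)O2)cc(OC)c1OC` differs from compound 1 by 2-(trifluoromethyl)phenyl in place of 3-fluorophenyl on a saturated ring carbon. The same 2-(trifluoromethyl)phenyl is present in compound 2 on a different core, where compound 2 gives 35.6%; that is the only hint at hand, and it points to no step beyond the scatter. Expected is a number 0.7 percentage points lower from compound 1 to compound 3 (within the scatter), a change of no more than the usual scatter in either direction. Compound 3 is estimated at 37%, in the range 20% to 55%.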

Compound 3, a percentage reported as inhibition, at one concentration (the size of the read-out at that concentration, not a potency): 34.8%
Compound 3: middle estimate off by 2.2 percentage points, on the high side, within the range that was stated.
By their numbers in this assay, from the lowest: compounds 3, 2 and 1 (each within the scatter of the next).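

In this assay, the saturated ring carbon of the shared core accepts 2-(trifluoromethyl)phenyl in place of 3-fluorophenyl with a number 2.9 percentage points lower from compound 1 to compound 3 (within the scatter), so this pair separates no aryl preference at this position. The swap raises the group from 7 to 10 heavy atoms and changes where the fluorine-bearing substituent sits on the phenyl ring, yet the read-out at the one concentration tested shows no order between the two compounds. Nothing at hand explains this outcome.

Both aryl groups shown carry only fluorine-containing substituents, so the effect of a phenyl bearing an amine or a carboxylic acid at this carbon remains open. Also open, on these data alone, is whether a longer chain, such as a propanoyl group in place of the acetyl group on the ring nitrogen, would shift the read-out.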